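Isopropyl in Place of Cyclopentyl: Compound 2 to Compound 4

The compounds below may be only part of what the source reports. "The series", "measured", "known", "first", "only" and "open" are said of these compounds alone.

Compound 1, `COc1cccc(OCCC(C)(C)C)c1C(=O)/C=C/c1ccc(O)cc1`: > 30000 nM
Compound 2, `O=C(/C=C/c1ccc(O)cc1)c1c(O)cccc1OCC1CCCC1`: 3410 nM
Compound 3, `CC(C)(C)CCOc1cccc(O)c1C(=O)/C=C/c1ccc(S(N)(=O)=O)cc1`: 2110 nM

In a functional assay on MDA-MB-231 cells (Homo sapiens) for antiproliferative activity, read by sulforhodamine B assay (a higher number here means a weaker inhibitor of growth, a lower number a stronger inhibitor of growth), compound 2 gives 3410 nM, the higher of the two numbers shown. Compound 3 gives 2110 nM, which lies within the scatter of compound 2. For compound 1 the assay reports only a limit, (the limit of > 30000 nM in this assay, at which 1 of the 3 values shown sits), not a number.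

Compound 4, `CC(C)COc1cccc(O)c1C(=O)/C=C/c1ccc(O)cc1`, differs from compound 2 by isopropyl in place of cyclopentyl on a saturated chain carbon bound to an oxygen on an aromatic ring. Within the data shown here, no step between two measured compounds is available to guide the size of this change, so the expectation rests on the small change in the ether group alone. Compound 4 is expected to stay close to compound 2, with a step of a 1.5-fold higher number from compound 2 to compound 4 (0.17 log units; within the scatter) that may not exceed the scatter. Compound 4 is thus estimated at 5000 nM, between 2000 nM and 15000 nM.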

Compound 4, concentration for 50% growth inhibition: 3520 nM
For compound 4 the middle estimate is 1.4-fold (0.15 log units) above the measured one; the range from low to high includes it.
By their numbers in this assay, from the lowest: compounds 3, 2 and 4 (each within the scatter of the next). At a limit, above all of these: compound 1.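

Isopropyl in place of cyclopentyl gives a 1.0-fold higher number from compound 2 to compound 4 (0.01 log units; within the scatter) in this assay, the first step read at this position. The ring of cyclopentyl can thus give way to the open isopropyl without a change beyond the scatter, so cyclopentylmethoxy and isobutoxy cannot be told apart here. Nothing measured among these compounds bears on why the two groups read alike. Still open, as far as these compounds go, is whether a group of another kind at this place, such as an amine, a carboxylic acid or a longer chain, would read the same.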